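Adenosine-based amine series: cyclopentyl to vinyl

A few compounds are considered here, and "the series" means these few. Any claim that something is new, unique, unknown or untested is made for them only; others in the source may bear on it.

Three amino-acid-bearing adenosine derivatives make up this set, differing only in the group carried on the amine nitrogen. Compound 1 `CCCN(CC[C@H](N)C(=O)O)C[C@H]1O[C@@H](n2cnc3c(N)ncnc32)[C@H](O)[C@@H]1O` carries a propyl group; in an assay for inhibition of tRNA (cytosine(38)-C(5))-methyltransferase (Homo sapiens), with a stated time of 5 min, tested at 100 uM (on this read-out higher numbers stand for more inhibition at the one concentration tested (going by the name of the read-out) and lower numbers for less inhibition), compound 1 gives no result reported. Compound 2 `Nc1ncnc2c1ncn2[C@@H]1O[C@H](CN(CC[C@H](N)C(=O)O)CC2CCCC2)[C@@H](O)[C@H]1O` carries a cyclopentylmethyl group, and in this assay compound 2 gives 24.5%. Within the data shown here, that is the only number in hand for this assay, so compound 2 serves as the sole reference point; there is no measured pair from which the size of a step could be read.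

Compound 3 `C=CCN(CC[C@H](N)C(=O)O)C[C@H]1O[C@@H](n2cnc3c(N)ncnc32)[C@H](O)[C@@H]1O` is the next member. Relative to compound 2 the change is vinyl in place of cyclopentyl on a saturated chain carbon bound to an amine nitrogen. Among the measured compounds shown here, with no measured step to go by, the expectation is that the step from compound 2 to compound 3 will be small and within the usual scatter, leaning if anything toward less inhibition, which is expressed as a number 6.5 percentage points lower from compound 2 to compound 3 (within the scatter). Accordingly compound 3 is estimated to give 18% in this assay, with a range from 4% to 34%.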

Compound 3, a percentage reported as inhibition, at one concentration (the size of the read-out at that concentration, not a potency): 53.9%
Estimate against measurement, compound 3: 35.9 percentage points below, outside the stated range (above it).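

On the amine nitrogen, the position is not indifferent to the group it carries: in this assay the change from cyclopentyl to vinyl on a saturated chain carbon bound to an amine nitrogen, which reads as cyclopentylmethyl to allyl when cut one bond further out, gives a number 29.4 percentage points higher from compound 2 to compound 3 (beyond the scatter) and so places the two compounds apart. In this single pair, the smaller group, with no ring and one double bond outside aromatic rings, goes with more inhibition at the one concentration tested, but the pair changes heavy-atom count, ring and double bond together and cannot separate them. Nothing at hand bears on why the read-out moves in this way.

On these data alone, compound 1, the propyl member, stands at no result reported in this assay, so the steps involving it cannot be read, and it remains open whether the double bond of allyl or the loss of the ring accounts for the step. Also open, as far as these compounds go, is where benzyl, cyclohexylmethyl or a longer chain on the same amine nitrogen would fall relative to these two compounds.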